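The compounds below may be only part of what the source reports. "The series", "measured", "known", "first", "only" and "open" are said of these compounds alone.

The measured compounds so far:

compound 1, `COc1ccccc1N1C(=O)CSC1C(=O)NCCCCc1ccccc1`: > 1000 nM
compound 2, `COc1ccc(F)cc1N1C(=O)CSC1c1cccc(C(=O)NCCCCn2cccn2)c1`: 97.3 nM
compound 3, `COc1cc(F)ccc1N1C(=O)CSC1c1cccc(C(=O)NCCCCc2ccccc2)c1`: 71.1 nM

All three were tested in a functional assay on HOS-TE85 cells (Homo sapiens) for inhibition, read by CCK-8 assay, with a stated time of 72 h; on this read-out lower numbers stand for stronger inhibition and higher numbers for weaker inhibition. For compound 1 this assay returns only a limit, > 1000 nM, and so no number is known for it; this is the limit of > 1000 nM in this assay, at which 1 of the 3 values shown sits. Compound 2 gives 97.3 nM in this assay, and compound 3 gives 71.1 nM. Compound 3 therefore holds the lowest of the two numbers, yet the gap to compound 2 lies within the usual scatter of the assay, so the two cannot be told apart on these data. The next compound, compound 4 `O=C(NCCCCc1ccccc1)c1cccc(C2SCC(=O)N2c2ccc(C3CC3)cc2)c1`, is built on the same core as compound 3 and differs from it in one place: 4-cyclopropylphenyl in place of 4-fluoro-2-methoxyphenyl on an amide-type nitrogen in a ring.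

Among the compounds with values here, no pair among the measured compounds shows a change of this kind, so there is no measured step to lean on. The expectation is that the change will move the number only modestly, in either direction, and the step is estimated as a 1.5-fold higher number from compound 3 to compound 4 (0.19 log units; within the scatter). Compound 4 is accordingly expected to give about 110 nM in this assay, most likely between 30 nM and 400 nM.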

Compound 4, half-maximal inhibitory concentration: 217 nM
Beside the measured number, compound 4's estimate is 2.0-fold (0.30 log units) below it, within the range that was stated.
By their numbers in this assay, from the lowest: compounds 3 and 2 (each within the scatter of the next); then compound 4. At a limit, above all of these: compound 1.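

Within the data shown here, on the amide-type nitrogen in the ring, putting 4-cyclopropylphenyl in place of 4-fluoro-2-methoxyphenyl gives a 3.1-fold higher number from compound 3 to compound 4 (0.48 log units; beyond the scatter) in this assay, the first measured step at this position, and it lies beyond the scatter. This position is therefore sensitive to the group it carries, although the weaker inhibition of compound 4 still gives a real number and not a limit, and the two groups match in heavy-atom count, so that count alone does not separate them; they differ in that the group leaving holds a hydrogen-bond acceptor and the group entering holds none. Nothing measured here explains why this change raises the number.

This single change removes the methoxy and the fluorine and adds the cyclopropyl all at once, so the compounds shown cannot tell which of these parts accounts for the step. Going by these compounds, it also remains open how the number would respond to a phenyl ring carrying an amine or a carboxylic acid in place of the cyclopropyl.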